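Propyl for phenyl on the imine carbon of compound 2

The source may hold more compounds than are shown below. What is called first, only, known or untested is meant among the compounds shown, and "the series" means these compounds.

Compound 1 `O=c1[nH]c2ccccc2cc1/C=N/c1ccccc1O` and compound 2 `O=c1[nH]c2ccccc2cc1/C=N/Cc1ccccc1` share one core and differ only in the group bound to the double-bonded nitrogen. In a functional assay, read by spectrophotometry, with a stated time of 1 h (on this read-out higher numbers stand for weaker inhibition and lower numbers for stronger inhibition), compound 1 gives 1660000 nM, while compound 2 gives 3140000 nM; the gap between the two falls within the scatter of this assay, so neither can be placed ahead of the other. Compound 3 `CCCC/N=C/c1cc2ccccc2[nH]c1=O` has not been measured. It differs from compound 2 by propyl in place of phenyl on a saturated chain carbon bound to a double-bonded nitrogen. Going by the values given here, with no comparable step among the measured pair to lean on, the step from a 1.3-fold higher number from compound 2 to compound 3 (0.11 log units; within the scatter) is expected to stay within the scatter, or at most slightly toward weaker inhibition. Compound 3 is therefore estimated at 4000000 nM, in a range from 1500000 nM to 10000000 nM.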

Compound 3, half-maximal inhibitory concentration: 7680000 nM
Estimate against measurement, compound 3: 1.9-fold (0.28 log units) below; low and high end bracket the measured number.
By their numbers in this assay, from the lowest: compounds 1 and 2 (each within the scatter of the next); then compound 3.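

In this assay the change from phenyl to propyl on a saturated chain carbon bound to a double-bonded nitrogen gives a 2.4-fold higher number from compound 2 to compound 3 (0.39 log units; beyond the scatter) and is the only step shown. This position therefore does respond to the group it carries, though modestly, and here the loss of phenyl moves the read-out toward weaker inhibition. No measurement shown accounts for this shift.

Going by these compounds, whether a longer chain, or a chain ending in a carboxylic acid, would bring the number back toward that of compound 2 remains open. Also open, on these data alone, is whether cyclohexyl in place of phenyl would behave like phenyl or like propyl.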